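Adding a side chain to compound 1

The source may hold more compounds than are shown below. What is called first, only, known or untested is meant among the compounds shown, and "the series" means these compounds.

Going by the values given here, in an assay on nucleic acid with ribosomal RNA A-site as the target (on this read-out lower numbers stand for tighter binding and higher numbers for weaker binding), compound 1 (`NC1C[C@@H](N)[C@@H](O)C(O)[C@H]1OCSc1ccnc2cc(C(F)(F)F)ccc12`) gives 35000 nM and stands lowest of the two numbers so far. Compound 2 (`COc1ccc(CO[C@H]2C(N)C[C@@H](N)[C@@H](O)C2O)cc1`) gives 315000 nM on the same read-out, a gap beyond the scatter. These two compounds differ in more than one place, so their values show only that gap and say nothing about any single change. Compound 3 (`NCCCNCCO[C@H]1C(O)[C@@H](OCSc2ccnc3cc(C(F)(F)F)ccc23)C(N)C[C@H]1N`) has not yet been measured. It carries 2-((3-aminopropyl)amino)ethyl in place of hydrogen on an oxygen on a saturated carbon and otherwise keeps the core of compound 1. Among the compounds with values here, no measured pair isolates such a change, so the expectation is a judgement from the structures alone. A step toward tighter binding is expected, estimated as a 5.8-fold lower number from compound 1 to compound 3 (0.77 log units; beyond the scatter) and beyond the scatter. For compound 3 the estimated dissociation constant is 6000 nM (expected range 1200 nM to 25000 nM).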

Compound 3, dissociation constant: 1500 nM
Compound 3: middle estimate off by 4.0-fold (0.60 log units), on the high side; the measured number falls inside the stated range.
By their numbers in this assay, from the lowest: compound 3; then compound 1; then compound 2.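

In this assay, the oxygen on a saturated carbon of compound 1 proves open to substitution: placing 2-((3-aminopropyl)amino)ethyl there in place of hydrogen brings a 23-fold lower number from compound 1 to compound 3 (1.37 log units; beyond the scatter), a large step toward tighter binding. This is the first pair shown that differs in one place, so this gain can be tied to a single change, which the gap between compound 1 and compound 2 could not do. Nothing measured here bears on why binding tightens.

The compounds shown do not separate the part played by the two amine nitrogens from that of the chain itself, which a plain ethyl, a 2-aminoethyl or a longer polyamine chain on the same oxygen would help to settle. As far as these compounds go, whether the same chain would give a similar step on another hydroxy group of the shared core also stays open.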